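The compounds below may be only part of what the source reports. "The series", "measured", "known", "first", "only" and "open" are said of these compounds alone.

Compound 3 `N#CC1=C(NC(=S)Nc2ccc(Cl)cc2)N(c2ccc(S(N)(=O)=O)cc2)C2=C(C(=O)CCC2)C1c1ccc(Cl)cc1Cl` carries a 4-chlorophenyl on an amide-type nitrogen. In a functional assay on Ehrlich cells (Mus musculus) for cytotoxicity, read by trypan blue exclusion, with a stated time of 2 h, tested at 50 ug/mL (on this read-out higher numbers stand for a stronger effect at the one concentration tested and lower numbers for a weaker effect), compound 3 gives 100%, the highest of the three numbers measured, and both of its measured neighbours lie beyond the scatter from it. Compound 1 `CCCCNC(=S)NC1=C(C#N)C(c2ccc(Cl)cc2Cl)C2=C(CCCC2=O)N1c1ccc(S(N)(=O)=O)cc1`, with a butyl on that nitrogen, gives 35% in this assay, and compound 2 `C=CCNC(=S)NC1=C(C#N)C(c2ccc(Cl)cc2Cl)C2=C(CCCC2=O)N1c1ccc(S(N)(=O)=O)cc1`, with an allyl there, gives 33%. The steps of a number 65 percentage points higher from compound 1 to compound 3 (beyond the scatter) and a number 67 percentage points higher from compound 2 to compound 3 (beyond the scatter) are both large, whereas a number 2 percentage points lower from compound 1 to compound 2 (within the scatter) lies within the scatter.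

Compound 4 `N#CC1=C(NC(=S)Nc2ccc(Br)cc2)N(c2ccc(S(N)(=O)=O)cc2)C2=C(C(=O)CCC2)C1c1ccc(Cl)cc1Cl` differs from compound 3 by bromo in place of chloro on an aromatic carbon. Among the compounds with values here, no measured step exchanges one halogen for another on this ring, so none bears directly on the change; the two large steps that reach compound 3 exchange the whole group on the amide-type nitrogen, an alkyl chain for an aryl ring, and compound 4 keeps that aryl ring. The read-out of compound 3 also sits at the top of the scale, leaving no room upward. The step of a number 5 percentage points lower from compound 3 to compound 4 (within the scatter) is therefore expected to be small, not beyond the scatter, with any deviation downward. Compound 4 is expected to give about 95% in this assay, between 80% and 100%.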

Compound 4, a percentage reported as activity, at one concentration (the size of the read-out at that concentration, not a potency): 90%
Compound 4: middle estimate off by 5 percentage points, on the high side; the range from low to high includes it.
By their numbers in this assay, from the lowest: compounds 2 and 1 (each within the scatter of the next); then compounds 4 and 3 (each within the scatter of the next).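

In this assay, a number 10 percentage points lower from compound 3 to compound 4 (within the scatter), so on this aromatic carbon, para to a large group, bromo and chloro cannot be told apart, although compound 3 at 100% stands at the top of the scale and a gain from the exchange could not have shown. The separation from the open chains does not depend on chloro alone: with 4-bromophenyl on the amide-type nitrogen there is a number 55 percentage points higher from compound 1 to compound 4 (beyond the scatter) and a number 57 percentage points higher from compound 2 to compound 4 (beyond the scatter), so both halogen-bearing aryl groups stand well clear of butyl and allyl. Nothing available on these compounds accounts for the separation between the aryl groups and the chains.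

Going by these compounds, whether the halogen is needed at all remains open, since only chloro and bromo appear here, and an unsubstituted phenyl, a 4-methoxyphenyl or a 4-fluorophenyl on the same nitrogen would test this. With a single concentration and numbers this close to the top of the scale, any difference between compound 3 and compound 4 in the strength of their effect at other concentrations also stays unresolved, and a dose series would be needed to address it.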